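Benzoyl on the Ring Nitrogen of Compound 1

The source may hold more compounds than are shown below. What is called first, only, known or untested is meant among the compounds shown, and "the series" means these compounds.

Compound 1 `Nc1nccn2cc(-c3ccccc3)nc12` is the reference point of this small set. In an assay on cells for displacement of a labelled ligand from adenosine receptor A1 (Homo sapiens), read by scintillation counting, with a stated time of 120 min, tested at 1 uM (on this read-out higher numbers stand for more inhibition at the one concentration tested (going by the name of the read-out) and lower numbers for less inhibition), compound 1 gives 30%, the highest of the three numbers measured. Compound 3 `Nc1nccn2cc(-c3ccco3)nc12` gives 21%, a number within the usual scatter of that of compound 1, so the two cannot be ordered. Within the data shown here, compound 2 `COc1ccc(-c2cn3ccnc(N)c3n2)cc1` gives 1%, and the step of a number 29 percentage points lower from compound 1 to compound 2 (beyond the scatter) is the one change that is clearly beyond the scatter: a methoxy in place of hydrogen on an aromatic carbon lowered the read-out modestly.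

Compound 4 `O=C(Nc1nccn2cc(-c3ccccc3)nc12)c1ccccc1` differs from compound 1 by benzoyl in place of hydrogen on a nitrogen on an aromatic ring. Among the measured compounds shown here, the only measured step, from compound 1 to compound 2, concerns a substituent on an aromatic carbon and so bears on this change only loosely; the set holds no step in which the nitrogen on the aromatic ring carries anything other than hydrogen. For the measured compounds named here, with that one step as the sole guide, the expectation is that placing a benzoyl on that nitrogen lowers the read-out of compound 4 by a modest amount, about a number 15 percentage points lower from compound 1 to compound 4 (beyond the scatter). Compound 4 is therefore estimated at 15%, with a range from 0% to 35%.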

Compound 4, a percentage reported as inhibition, at one concentration (the size of the read-out at that concentration, not a potency): 18%
Compound 4: middle estimate off by 3 percentage points, on the low side, within the range that was stated.
By their numbers in this assay, from the lowest: compound 2; then compounds 4, 3 and 1 (each within the scatter of the next, the first and the last beyond it).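

With compound 4, the set gains its first change on the nitrogen on an aromatic ring, and in this assay the step of a number 12 percentage points lower from compound 1 to compound 4 (beyond the scatter) shows that this nitrogen is not a silent place: replacing its hydrogen with benzoyl, which brings 8 heavy atoms and a six-membered aromatic ring, moves the read-out by a modest amount. The number is lowered but not abolished, as compound 4 still gives 18% at the one concentration tested, and this reading holds for benzoyl alone. No measurement at hand accounts for this step, so the reason for it remains unknown.

On these data alone, what remains open is whether the step belongs to the carbonyl or to the aromatic ring of the benzoyl, which an acetyl or a plain methyl on the same nitrogen could help to separate. Equally open, as far as these compounds go, is how a longer chain or an amine-bearing acyl group at this nitrogen would read, and whether benzoyl would have the same effect on compound 3, which carries a different group on the shared core.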